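The compounds below may be only part of what the source reports. "The series", "measured", "known", "first", "only" and "open" are said of these compounds alone.

Measured in an ADME assay on MDCK cells (Canis lupus familiaris) for cytotoxicity, read by MTT assay, with a stated time of 72 h; a higher number here means that more compound is tolerated, a lower number that less compound is tolerated:
- compound 1 `CC(=O)Nc1ccc(S(=O)(=O)n2cc([N+](=O)[O-])nc2C)cc1`: 1030000 nM
- compound 2 `Cc1nc([N+](=O)[O-])cn1CC(=O)Nc1ccc(C#N)cc1`: 672000 nM

In this assay compound 1 gives 1030000 nM and compound 2 gives 672000 nM. These two values lie within the usual scatter of each other, so compound 1 does not stand apart from compound 2.

Compound 3 `COc1ccc(S(=O)(=O)n2cc([N+](=O)[O-])nc2C)cc1` is not yet measured. It carries methoxy in place of acetamido on an aromatic carbon, para to a large group (methoxy in place of acetamido on an aromatic carbon).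

Going by the values given here, no measured pair differs in one place, so the data offer no direct guide to this change. No step beyond the scatter is expected in this assay, in either direction. The expectation starts from compound 1 at 1030000 nM.

The estimated change is a 1.3-fold lower number from compound 1 to compound 3 (0.11 log units; within the scatter), which stays within the scatter. For compound 3 the expected value is 800000 nM, with an estimated range of 350000 nM to 1800000 nM.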

Compound 3, half-maximal cytotoxic concentration: 321000 nM
Estimate against measurement, compound 3: 2.5-fold (0.40 log units) above; the whole stated range lies above it.
By their numbers in this assay, from the lowest: compound 3; then compounds 2 and 1 (each within the scatter of the next).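

In this assay, going by these compounds alone, methoxy in place of acetamido on an aromatic carbon, para to a large group, gives a 3.2-fold lower number from compound 1 to compound 3 (0.51 log units; beyond the scatter) and is the only step that can be read directly. It shows that this position is not indifferent to its substituent: with the rest of the core of compound 1 unchanged, this exchange goes with less compound being tolerated. No measured evidence bears on what lies behind this step.

This single exchange removes the carbonyl, the amide hydrogen and two heavy atoms together, and the compounds shown do not separate these changes. Open too, on these data alone, is how the number would respond at this position to an amine, a carboxylic acid or a longer chain such as ethoxy, and whether any of these would keep the value of compound 1.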